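Ring Size of the Charged Tail in Three Promoter Inhibitors

The compounds below may be only part of what the source reports. "The series", "measured", "known", "first", "only" and "open" are said of these compounds alone.

In an assay on LX2 cells for inhibition of COL1A1 promoter (Homo sapiens), read by a luciferase reporter, with a stated time of 24 h, tested at 50 uM (on this read-out higher numbers stand for a stronger effect at the one concentration tested and lower numbers for a weaker effect), the three measured compounds give these numbers:
Compound 1, `Cc1cc(-n2cc(C(=O)Nc3cc(F)cc(F)c3)c(=O)c3ccc(N(C)C)nc32)ccc1OCCCCCCC[N+]1(C)CCCC1`, gives 35.9%.
Compound 2, `Cc1ccc(-n2cc(C(=O)Nc3cc(F)cc(F)c3)c(=O)c3ccc(N(C)C)nc32)cc1OCCCCCCC[N+]1(C)CCCC1`, gives 55.9%.
Compound 3, `Cc1cc(-n2cc(C(=O)Nc3cc(F)cc(F)c3)c(=O)c3ccc(N(C)C)nc32)ccc1OCCCCCCC[N+]1(C)CCCCC1`, gives 54.4%.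

Compound 1 and compound 2 are built from the same atoms joined differently; the difference between the two cores is not broken down here. Compound 3 keeps the core of compound 1 and changes only the charged ring at the end of the chain: a group of 7 heavy atoms (6 carbon, 1 nitrogen; one six-membered non-aromatic ring with 1 hetero atom) in place of a group of 6 heavy atoms (5 carbon, 1 nitrogen; one five-membered non-aromatic ring with 1 hetero atom), on a saturated chain carbon, seven bonds along the chain from an oxygen on an aromatic ring. This single change gave a number 18.5 percentage points higher from compound 1 to compound 3 (beyond the scatter), so in this series a larger ring at the end of the chain went with a stronger effect. Compound 2 and compound 3 lie within the scatter of each other in this assay, while compound 2 stands beyond the scatter from compound 1.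

Compound 4, `Cc1ccc(-n2cc(C(=O)Nc3cc(F)cc(F)c3)c(=O)c3ccc(N(C)C)nc32)cc1OCCCCCCC[N+]1(C)CCCCC1`, has not yet been measured. It relates to compound 2 as compound 3 relates to compound 1: a group of 7 heavy atoms (6 carbon, 1 nitrogen; one six-membered non-aromatic ring with 1 hetero atom) in place of a group of 6 heavy atoms (5 carbon, 1 nitrogen; one five-membered non-aromatic ring with 1 hetero atom), on a saturated chain carbon, seven bonds along the chain from an oxygen on an aromatic ring. The place of the change is the same, so this is the same change made on the other core.

For the measured compounds named here, the step from compound 2 to compound 4 in this assay is expected to be a number 8.1 percentage points higher from compound 2 to compound 4 (within the scatter), resting on the one measured example of this change, compound 1 to compound 3 with a number 18.5 percentage points higher from compound 1 to compound 3 (beyond the scatter), while allowing that compound 2 already starts higher than compound 1. Compound 4 is therefore estimated at 64%, expected to fall between 49% and 79%.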

Compound 4, a percentage reported as inhibition, at one concentration (the size of the read-out at that concentration, not a potency): 45.1%
Compound 4: middle estimate off by 18.9 percentage points, on the high side, and the stated range ends above it.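

On the core of compound 2, placing the charged six-membered ring where the five-membered ring stood gave a number 10.8 percentage points lower from compound 2 to compound 4 (beyond the scatter) in this assay. Set beside the earlier example, the same swap at the same place on the chain went in opposite directions on the two cores: the same change on two cores in this assay, a number 18.5 percentage points higher (beyond the scatter) from compound 1 to compound 3 and a number 10.8 percentage points lower (beyond the scatter) from compound 2 to compound 4, 29.3 percentage points apart, beyond the scatter of two such steps. For the compounds shown here, this shows that, in this small series, the result of the ring swap did not carry from one core to the other, so a step measured on one core was a poor guide to the same step on the other, even in its direction; it does not show why the direction reversed, and with only two pairs, it sets no rule for any further core.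

The compounds shown leave open how other groups at the end of the chain would behave on these two cores, such as a seven-membered ring, a morpholine ring or an uncharged tertiary amine, and whether a shorter or longer chain would keep the same reversal. They also leave open whether the reversal would persist at other concentrations, as each number gives the size of the effect at one concentration and not a potency.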